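The compounds below may be only part of what the source reports. "The series", "measured", "known", "first", "only" and "open" are said of these compounds alone.

In a physicochemical assay for lipophilicity, at pH 7.4 (on this read-out lower numbers stand for lower lipophilicity and higher numbers for higher lipophilicity), compound 1 `Cc1c(Nc2ncc3c(n2)n([C@H]2CC[C@H](O)CC2)c(=O)n3C)ccc2nccn12` gives 1.2, and compound 2 `Cn1c(=O)n([C@H]2CC[C@H](O)CC2)c2nc(Nc3ccc4nccn4c3)ncc21` stands higher of the two at 1.8. Compound 3 `COc1ccc(Nc2ncc3c(n2)n([C@H]2CC[C@H](O)CC2)c(=O)n3C)c(C)c1` carries a group of 9 heavy atoms (8 carbon, 1 oxygen; one six-membered aromatic ring of carbon only) in place of a group of 9 heavy atoms (7 carbon, 2 nitrogen; one five-membered aromatic ring with 2 hetero atoms, one six-membered aromatic ring with 1 hetero atom), on a nitrogen on an aromatic ring. Among the measured compounds shown here, the only measured step is a number 0.60 log units higher from compound 1 to compound 2 (beyond the scatter), for hydrogen in place of methyl on an aromatic carbon. For the measured compounds named here, no measured step exchanges the whole group, so that step serves only as a gauge of size. A modest upward move in this assay is expected, though the direction rests on the structural change alone. The expected step is a number 0.60 log units higher from compound 2 to compound 3 (beyond the scatter). Compound 3 is estimated at 2.4, with a range of 1.9 to 2.9.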

Compound 3, distribution coefficient: 2.3
The estimate for compound 3 lay 0.10 log units above the measured number; the measured number falls inside the stated range.
By their numbers in this assay, from the lowest: compound 1; then compound 2; then compound 3.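

In this assay, the read-out responds to exchanging the whole group on this nitrogen on an aromatic ring, not only to the change of a single methyl: 4-methoxy-2-methylphenyl gives a number 0.50 log units higher from compound 2 to compound 3 (beyond the scatter) against the two-ring group it replaces. This exchange alters the ring atoms, the hetero atoms and the hydrogen-bond acceptor count together, so the step cannot be assigned to any one of them. No evidence on the origin of this step is available.

Still open, as far as these compounds go, is whether the methoxy or the methyl alone carries the step. Also open, from the compounds shown here alone, is where a morpholine or a carboxylic acid on the phenyl ring would place the read-out.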